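Halogen swap on the benzyl arm of a triazole-linked pyrazole amide

A few compounds are considered here, and "the series" means these few. Any claim that something is new, unique, unknown or untested is made for them only; others in the source may bear on it.

Compound 1 `COc1cc(Cn2cc(CNC(=O)c3cn(-c4ccccc4)nc3-c3ccc(F)cc3)nn2)cc(OC)c1OC` and compound 2 `COc1cc(Cn2cc(CNC(=O)c3cn(-c4ccccc4)nc3-c3ccc(Cl)cc3)nn2)cc(OC)c1OC` share one core and differ only in the way told by chloro in place of fluoro on an aromatic carbon. In a functional assay on MCF7 cells (Homo sapiens) for antiproliferative activity, read by sulforhodamine B assay, with a stated time of 48 h (on this read-out lower numbers stand for stronger inhibition of growth and higher numbers for weaker inhibition of growth), compound 1 gives 4300 nM, and compound 2 gives 2500 nM; the step is a 1.7-fold lower number from compound 1 to compound 2 (0.24 log units; within the scatter), so the two numbers cannot be told apart.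

Compound 3 `COc1ccc(-c2nn(-c3ccccc3)cc2C(=O)NCc2cn(Cc3ccc(F)cc3)nn2)cc1` belongs to a second core; the difference between the two cores is not broken down here. In this assay compound 3 gives 460 nM, a lower number than compound 2 and compound 1 by margins that lie beyond the scatter.

Compound 4 `COc1ccc(-c2nn(-c3ccccc3)cc2C(=O)NCc2cn(Cc3ccc(Cl)cc3)nn2)cc1` has not been measured. It differs from compound 3 as told by chloro in place of fluoro on an aromatic carbon. The place is worded as in the change from compound 1 to compound 2, on an aromatic carbon of a six-membered aromatic ring of carbon only, para to a large group; read one bond further out, the change here is also 4-fluorobenzyl to 4-chlorobenzyl, which the earlier change does not carry, so it is taken as the same kind of change on a different arm of the molecule.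

Within the data shown here, the only precedent, a 1.7-fold lower number from compound 1 to compound 2 (0.24 log units; within the scatter), is within the scatter, so the expected step is small, a 1.3-fold lower number from compound 3 to compound 4 (0.12 log units; within the scatter), resting on compound 2 at 2500 nM against compound 1 at 4300 nM. Compound 4 is estimated at 350 nM, expected to fall between 150 nM and 900 nM.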

Compound 4, concentration for 50% growth inhibition: 2900 nM
Compound 4: the middle estimate sits 8.3-fold (0.92 log units) below what was measured, outside the stated range (above it).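

In this assay, chloro in place of fluoro on the core of compound 3 gives a 6.3-fold higher number from compound 3 to compound 4 (0.80 log units; beyond the scatter), so on this core the change costs growth inhibition, and the step does not match the one seen on the other core: the same change on two cores in this assay, a 1.7-fold lower number (0.24 log units; within the scatter) from compound 1 to compound 2 and a 6.3-fold higher number (0.80 log units; beyond the scatter) from compound 3 to compound 4, 11-fold (1.04 log units) apart, beyond the scatter of two such steps

A change that made no readable difference on one core therefore cannot be assumed to be harmless on another, and the earlier pair gives no guide to the size or direction of the step here. What this does not show is the source of the gap: the two pairs differ in core, and the swap also sits on different arms, 4-fluorophenyl to 4-chlorophenyl in one and 4-fluorobenzyl to 4-chlorobenzyl in the other, so core and arm cannot be separated, and with one pair on each core no rule for the series follows.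

As far as these compounds go, it remains open whether the size of the step follows the core or the arm that carries the halogen. Also open, from the compounds shown here alone, is how a bromo group, a nitrile or plain hydrogen at the same place on the benzyl arm of compound 3 would read in this assay.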